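Shared-core series: cytotoxicity outlook for compound 4

This account rests on a few compounds, and the source may have more. Where it says the series, first, only, none or still open, it means among the compounds named here.

Cytotoxicity is read in an ADME assay on HepG2 2.2.15 cells (Homo sapiens) for cytotoxicity; a lower number here means that less compound is tolerated, a higher number that more compound is tolerated. Compound 1 `Cc1ccc(C(=O)Nc2ncc(Cc3ccc(F)cc3)s2)cc1` gives "not toxic" (no number reported). Compound 2 `CC(C)(C)OC(=O)Nc1ncc(C(Oc2ccc(F)c(Cl)c2)c2ccc(Cl)cc2)s1` reaches only a limit of the assay, > 50000 nM. Compound 3 `CCCCC(CC)CNc1ncc(C(Oc2ccc3cc(Br)ccc3c2)c2ccc(Cl)cc2)s1` is recorded as "not toxic" (no number reported), so no single number places it. Among the three values shown, one further is an entry without a number, and one further sits at a limit of the assay (the limit of > 50000 nM in this assay, at which 1 of the 3 values shown sits). Compound 4 `CCN(CC)C(=O)Nc1ncc(C(Oc2ccc3cc(Br)ccc3c2)c2ccc(Cl)cc2)s1` differs from compound 3 by diethylcarbamoyl in place of 2-ethylhexyl on a nitrogen on an aromatic ring. Among the measured compounds shown here, no measured step exists in this set, and none of the three values gives a number, so no change beyond the scatter is expected in this assay in either direction. Compound 4 is expected to show 50000 nM, within 20000 nM to 200000 nM, most likely as a limit only.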

Compound 4, half-maximal cytotoxic concentration: "not toxic" (no number reported)
Compound 4 has no reported number here; the estimate stays without a comparison.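

Compound 3 and compound 4 both stand in this assay without a number, so no new step can be read. The compounds shown leave open whether diethylcarbamoyl in place of 2-ethylhexyl shifts the tolerated concentration, and the only other entry with a value gives no exact figure: the limit of > 50000 nM in this assay, at which 1 of the 4 values shown sits.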